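A Phenyl Group Placed on the Hydroxyl of Compound 2

A few compounds are considered here, and "the series" means these few. Any claim that something is new, unique, unknown or untested is made for them only; others in the source may bear on it.

Of the compounds shown here, two have been measured in an assay on a cell-free system (plasma) for antagonist activity at proteinase-activated receptor 4 (Homo sapiens), with a stated time of 5 min, in the presence of a further agent that is not named here; a higher number here means a weaker inhibitor, a lower number a stronger inhibitor. Compound 1 `COc1nn2cc(-c3cc4ccc(OCc5ccccc5)cc4o3)nc2s1` does not give a number in this assay but only a limit, > 30000 nM, which is the limit of > 30000 nM in this assay, at which 1 of the 2 values shown sits. Within the data shown here, compound 2 `COc1cc(OCc2cccc(O)c2)c2cc(-c3cn4nc(OC)sc4n3)oc2c1` gives 2700 nM in this assay, and this is the only number among the values shown. Among the measured compounds shown here, the one further value, that of compound 1, is a limit. Compound 2 therefore stands alone as the sole measured inhibitor, without any second number to rank it against.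

Compound 3 `COc1cc(OCc2cccc(Oc3ccccc3)c2)c2cc(-c3cn4nc(OC)sc4n3)oc2c1` has not yet been measured. It differs from compound 2 by phenyl in place of hydrogen on an oxygen on an aromatic ring. For the measured compounds named here, no measured pair tracks that change, so its size cannot be read from any measured step. The author expects the step from compound 2 to compound 3 to amount to a 1.9-fold higher number from compound 2 to compound 3 (0.27 log units; within the scatter), a move toward weaker inhibition that may well stay within the usual scatter. The estimate for compound 3 in this assay is 5000 nM, with a range from 1500 nM to 20000 nM.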

Compound 3, half-maximal inhibitory concentration: 390 nM
Compound 3: middle estimate off by 13-fold (1.11 log units), on the high side; measured number outside the range, below it.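

In this assay, the change from hydroxy to phenoxy on the aromatic ring gives a 6.9-fold lower number from compound 2 to compound 3 (0.84 log units; beyond the scatter), a step beyond the usual scatter and toward stronger inhibition. Among these compounds, this is the first measured step, and it shows that the oxygen on this aromatic ring can carry a phenyl group in place of hydrogen with inhibition retained and improved, so in this pair the free hydroxy group is not needed for activity. No measurement shown here accounts for the size of this step.

Among the compounds shown here, with only this pair, it remains open whether the gain depends on the phenyl ring itself or would also appear with a smaller group on the same oxygen, such as methyl, or with a longer chain such as benzyl. As far as these compounds go, it is also open how far a substituent on the new phenyl ring, such as an amine or a carboxylic acid, would shift the result, and whether the same change would give a similar step on a different core.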